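The source may hold more compounds than are shown below. What is called first, only, known or untested is meant among the compounds shown, and "the series" means these compounds.

Measured so far in a functional assay on MDA-MB-231 cells (Homo sapiens) for antiproliferative activity, read by MTT assay, with a stated time of 72 h; on this read-out lower numbers stand for stronger inhibition and higher numbers for weaker inhibition:

compound 1 `CN(C)CCn1cnnc1-c1cc(Oc2ccc(NC(=O)Nc3ccc(F)c(Cl)c3)cc2F)ccn1` — 8320 nM
compound 2 `CN(C)CCCn1cnnc1-c1cc(Oc2ccc(NC(=O)Nc3cccc(C(F)(F)F)c3)cc2F)ccn1` — 13300 nM

Compound 2 and compound 1 lie within the scatter of each other in this assay; their two numbers do not separate. Compound 1 differs from compound 2 in more than one place, so no single step can be read between them, and the two values only show that both sit in the same weak range.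

Compound 3 `CN(C)CCCn1cnnc1-c1cc(Oc2ccc(NC(=O)Nc3ccc(F)c(Cl)c3)cc2F)ccn1` has not yet been measured. It differs from compound 2 in one place: 3-chloro-4-fluorophenyl in place of 3-(trifluoromethyl)phenyl on an amide-type nitrogen. Going by the values given here, the group that enters is the one already carried by compound 1, whose value of 8320 nM lies within the scatter of compound 2. Nothing in the measured pair therefore points to a step beyond the scatter in either direction. The expected step from compound 2 to compound 3 is a 1.5-fold lower number from compound 2 to compound 3 (0.17 log units; within the scatter), small and within the usual spread. Compound 3 is estimated at 9000 nM, with a range from 3500 nM to 23000 nM.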

Compound 3, half-maximal inhibitory concentration: 14200 nM
Compound 3: the middle estimate sits 1.6-fold (0.20 log units) below what was measured, within the range that was stated.
By their numbers in this assay, from the lowest: compounds 1, 2 and 3 (each within the scatter of the next).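

In this assay the amide-type nitrogen now gives its first reading with one place varied: 3-chloro-4-fluorophenyl in place of 3-(trifluoromethyl)phenyl gives a 1.1-fold higher number from compound 2 to compound 3 (0.03 log units; within the scatter) and so the two groups do not separate at this position. With 3-chloro-4-fluorophenyl held constant, the chain can also be read, and (dimethylamino)methyl in place of dimethylamino on a saturated chain carbon, two bonds along the chain from an aromatic nitrogen, gives a 1.7-fold higher number from compound 1 to compound 3 (0.23 log units; within the scatter) and so this change does not separate the compounds either. Neither single change therefore moves the series out of the weak range seen so far, and no measured evidence is available to account for these results.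

Still open, from the compounds shown here alone, is whether a different group on the amide-type nitrogen, such as unsubstituted phenyl or 4-methoxyphenyl, would give a step beyond the scatter in this assay. Going by these compounds, it is equally open whether a morpholine or a piperazine in place of dimethylamino at the end of the chain, or a longer chain, would separate from these three compounds.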